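Cytotoxicity of Three Purine Analogues Differing at One Position

A few compounds are considered here, and "the series" means these few. Any claim that something is new, unique, unknown or untested is made for them only; others in the source may bear on it.

Measured so far:
compound 1, `CCCSc1nc(N)nc2c1ncn2/C=C1/C[C@@H]1CO`, 283000 nM
compound 2, `CCCOc1nc(N)nc2c1ncn2/C=C1/C[C@@H]1CO`, 69400 nM

Both were tested in a functional assay on HFF cells (Homo sapiens) for cytotoxicity; a lower number here means that less compound is tolerated, a higher number that more compound is tolerated. Compound 2 has the lowest number of the two, and its nearest neighbour is compound 1, whose number is higher; the step of a 4.1-fold lower number from compound 1 to compound 2 (0.61 log units; beyond the scatter) lies beyond the scatter and is of modest size.

Compound 3, `C=CCNc1nc(N)nc2c1ncn2/C=C1/C[C@@H]1CO`, has not yet been measured. It differs from compound 2 in one place: allylamino in place of propoxy on an aromatic carbon. For the measured compounds named here, the only step measured so far, a 4.1-fold lower number from compound 1 to compound 2 (0.61 log units; beyond the scatter), concerns a different exchange at this same position, so it does not directly tell what an allylamino group will do; it shows only that changes at this carbon can shift the number beyond the scatter in either direction. Going by the values given here, with no closer precedent, the step of a 1.4-fold higher number from compound 2 to compound 3 (0.16 log units; within the scatter) is expected to stay small or moderate, with no confident direction. Compound 3 is therefore estimated at 100000 nM in this assay, within a range from 30000 nM to 400000 nM.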

Compound 3, half-maximal cytotoxic concentration: > 368000 nM
Compound 3: no number, only a limit; the forecaster's own chance of this, stated with the estimate: 20%; at least 3.6-fold (0.56 log units) between middle value and limit.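

Compound 3 has no exact number, only a limit of the assay: the limit of > 368000 nM in this assay, at which 1 of the 3 values shown sits.

In this assay, for the compounds shown here, the exchange of propoxy for allylamino on this aromatic carbon gives an at least 5.3-fold higher number from compound 2 to compound 3 (0.72 log units; beyond the scatter), so this change raises the number clearly, whereas the earlier compounds showed only that propoxy gave a lower number than propylsulfanyl. Set against the sulfur-linked chain, allylamino gives an at least 1.3-fold higher number from compound 1 to compound 3 (0.11 log units; that floor lies within the scatter), and because that floor lies within the scatter, no order can be stated for these two groups, while compound 2 stays clearly the lowest of the three.

The compounds shown leave open whether the shift goes with the linking nitrogen or with the double bond of allylamino, as the two enter together; a propylamino group would have the nitrogen without the double bond, and an allyloxy group the double bond without the nitrogen. From the compounds shown here alone, how far the tolerated concentration of compound 3 really lies past its limit also stays open, as does the effect of a shorter chain such as methylamino at this carbon.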